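This account rests on a few compounds, and the source may have more. Where it says the series, first, only, none or still open, it means among the compounds named here.

Compound 1 `COc1ccc(-c2ccc(-c3ccc(C(=N)N)cc3)s2)cc1` and compound 2 `N=C(N)c1ccc(-c2ccc(-c3cc(Cl)cc(Cl)c3)s2)cc1` share the same core and differ only in the outer ring. In a functional assay on NCI-H226 cells (Homo sapiens) for inhibition, read by sulforhodamine B assay, with a stated time of 48 h (on this read-out higher numbers stand for weaker inhibition of growth and lower numbers for stronger inhibition of growth), compound 1 gives 2140 nM, and compound 2 gives 2090 nM. Among the compounds with values here, of these two numbers the one for compound 1 stands highest, yet its gap to compound 2 lies within the scatter, so the two cannot be told apart. Compound 3 `N=C(N)c1ccc(-c2ccc(-c3ccc(F)cc3)s2)cc1` has not yet been measured; it differs from compound 1 by fluoro in place of methoxy on an aromatic carbon. Within the data shown here, no measured step covers this change, so in this assay a step of no more than the scatter, in no set direction, is expected: a 1.2-fold higher number from compound 1 to compound 3 (0.07 log units; within the scatter). Compound 3 is estimated at 2500 nM, within 800 nM to 8000 nM.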

Compound 3, concentration for 50% growth inhibition: 2190 nM
Compound 3: the middle estimate sits 1.1-fold (0.06 log units) above what was measured, and the stated range covers the measured number.
By their numbers in this assay, from the lowest: compounds 2, 1 and 3 (each within the scatter of the next).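

In this assay, fluoro in place of methoxy on an aromatic carbon, para to a large group, gives a 1.0-fold higher number from compound 1 to compound 3 (0.01 log units; within the scatter) and so stays within the scatter. At this position, the read-out therefore does not separate methoxy, which counts one hydrogen-bond acceptor, from fluoro, which counts none. Nothing measured here bears on the reason for this result.

Going by these compounds, whether an amine or a carboxylic acid at this position would move the number beyond the scatter remains open. The same question stands for a longer chain such as butoxy.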